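Adding One Methoxy Group to Compound 2

The source may report more compounds than this note shows. Statements on the series, on what has been measured and on what is new or still open speak of the compounds shown alone.

- compound 1 `COc1ccc(C2=NN(c3nc(-c4ccccc4)c(C#N)c(=O)n3C)C(c3ccc(OC)cc3)C2)cc1` gives 16200 nM
- compound 2 `COc1ccc(C2CC(c3ccccc3)=NN2c2nc(-c3ccc(Cl)cc3)c(C#N)c(=O)n2C)cc1` gives 19500 nM

Both numbers come from a functional assay on MDA-MB-231 cells (Homo sapiens) for antiproliferative activity, with a stated time of 72 h (on this read-out lower numbers stand for stronger inhibition and higher numbers for weaker inhibition), and they sit within the usual scatter of each other, so compound 2 cannot be ranked against compound 1 on these data. The two compounds differ in more than one place, which means that no single structural change can be read from this pair.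

The next compound, compound 3 `COc1ccc(C2=NN(c3nc(-c4ccc(Cl)cc4)c(C#N)c(=O)n3C)C(c3ccc(OC)cc3)C2)cc1`, is compound 2 with methoxy in place of hydrogen on an aromatic carbon, para to a large group, so that a phenyl becomes a 4-methoxyphenyl (methoxy in place of hydrogen on an aromatic carbon). Going by the values given here, no measured pair shows this change alone. The only clue is indirect: compound 1 carries a 4-methoxyphenyl group and gives 16200 nM in the same range as compound 2. A change beyond the scatter in this assay is therefore not expected, in either direction. The expected step is a 1.1-fold lower number from compound 2 to compound 3 (0.06 log units; within the scatter) and it is only an estimate. For compound 3 the estimated value is 17000 nM with an expected range from 8000 nM to 36000 nM as the likely span.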

Compound 3, half-maximal inhibitory concentration: 28300 nM
Beside the measured number, compound 3's estimate is 1.7-fold (0.22 log units) below it; the range from low to high includes it.
By their numbers in this assay, from the lowest: compounds 1, 2 and 3 (each within the scatter of the next).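

Going by these compounds alone, compound 2 and compound 3 form the first pair that isolates the methoxy change: in this assay, turning a phenyl into a 4-methoxyphenyl, on an aromatic carbon para to a large group, gives a 1.5-fold higher number from compound 2 to compound 3 (0.16 log units; within the scatter). This means that, at this position, adding a methoxy group in place of hydrogen has no effect that can be told apart from ordinary assay noise, although one pair cannot show that the group is truly without effect. Compound 3 also provides a second single-place comparison, in which chloro in place of hydrogen on an aromatic carbon gives a 1.7-fold higher number from compound 1 to compound 3 (0.24 log units; within the scatter), so neither change can be read as a real difference, and no separate measurement helps to interpret these results.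

On these data alone, it remains open whether a different group at the same position, such as an amine, a carboxylic acid or a longer chain like butoxy, would move the number beyond the scatter. Whether methoxy would behave the same way on the other aromatic rings of the shared core also remains unanswered.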